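Swapping a hydroxy group for hydroxyamino on the shared core

The compounds below may be only part of what the source reports. "The series", "measured", "known", "first", "only" and "open" are said of these compounds alone.

Of the compounds shown here, two built on the same core have been measured in a functional assay, tested at 100 uM; on this read-out higher numbers stand for a stronger effect at the one concentration tested and lower numbers for a weaker effect. Compound 1, with the structure `COc1cc(Cn2cc(C(=O)O)c(=O)c3ccccc32)cc(OC)c1`, gives 47.6%, the higher of the two numbers. Compound 2, with the structure `O=C(NO)c1cn(Cc2ccc(Br)cc2)c2ccccc2c1=O`, gives 27.6% in this assay, a lower number, a gap that lies beyond the usual scatter. The two compounds differ in more than one place, so their values are simply two points rather than a single traced step.

Compound 3, with the structure `COc1cc(Cn2cc(C(=O)NO)c(=O)c3ccccc32)cc(OC)c1`, has not yet been measured. It differs from compound 1 in one place: hydroxyamino in place of hydroxy on a carbonyl carbon. Among the measured compounds shown here, compound 2 carries the same hydroxycarbamoyl group as compound 3 but a different benzyl substituent, so no measured pair isolates this change. With only that indirect hint, the expected step of a number 9.6 percentage points lower from compound 1 to compound 3 (within the scatter) is a mild fall, perhaps not beyond the scatter. Compound 3 is therefore expected to give about 38% in this assay, plausibly anywhere from 18% to 58%.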

Compound 3, a percentage reported as activity, at one concentration (the size of the read-out at that concentration, not a potency): 41.3%
For compound 3 the middle estimate is 3.3 percentage points below the measured one; the range from low to high includes it.
By their numbers in this assay, from the lowest: compound 2; then compounds 3 and 1 (each within the scatter of the next).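

In this assay, putting hydroxyamino in place of hydroxy on a carbonyl carbon, which turns carboxy into hydroxycarbamoyl, gives a number 6.3 percentage points lower from compound 1 to compound 3 (within the scatter). Among the compounds shown here, this is the first pair in which that change stands alone with the rest of the structure held fixed, and it shows that, with this benzyl substituent and at the one concentration tested, the read-out does not separate the two groups. No measurement at hand bears on why the two groups read so alike.

For the compounds shown here, a single pair at a single concentration leaves open whether the same swap would also stay within the scatter on a compound carrying a different benzyl substituent, and it gives no potency for either compound. From the compounds shown here alone, what a methyl ester or a plain primary amide would give on this carbonyl carbon also remains open, so the range of groups tolerated here cannot yet be judged from these compounds.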